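Three Measured Compounds and One Expected Value

The source may hold more compounds than are shown below. What is called first, only, known or untested is meant among the compounds shown, and "the series" means these compounds.

Compound 1 `CCCc1nc(-c2ccccc2)c(CNCCN2CCN(c3ccccc3Cl)CC2)o1`: 60.1%
Compound 2 `CCCc1nc(-c2ccccc2)c(CNCCCN2CCN(c3ccc(F)cc3)CC2)o1`: 62.5%
Compound 3 `Cc1nc(-c2ccccc2)c(CNCCN2CCN(C(c3ccccc3)c3ccccc3)CC2)o1`: 57.3%

All three were tested in an assay on HEK293 cells for inhibition of Voltage-dependent T-type calcium channel subunit alpha-1G (Homo sapiens), read by fluorescence, tested at 10 uM; a higher number here means more inhibition at the concentration tested (going by the name of the read-out), a lower number less inhibition. Compound 2 gives the highest of the three numbers, but compound 1 and compound 3 both lie within the usual scatter of it, so the three cannot be ranked on these values. Compound 1 reaches 60.1% and compound 3 reaches 57.3%, with compound 2 at 62.5% in this assay.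

Compound 4 `CCCc1nc(-c2ccccc2)c(CNCCCN2CCN(c3cccc(OC)c3)CC2)o1` is the next compound, not yet measured. It differs from compound 2 in one place: 3-methoxyphenyl in place of 4-fluorophenyl on an amine nitrogen in a ring. Going by the values given here, no two measured compounds differ in exactly one place, so no measured step is available to guide this change. Given that the three known numbers sit close together, compound 4 is expected to move by no more than the scatter in this assay, with the step of a number 4.5 percentage points lower from compound 2 to compound 4 (within the scatter). The estimate for compound 4 in this assay is 58%, within a range from 42% to 74%.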

Compound 4, a percentage reported as inhibition, at one concentration (the size of the read-out at that concentration, not a potency): 36.4%
Beside the measured number, compound 4's estimate is 21.6 percentage points above it, outside the stated range (below it).
By their numbers in this assay, from the lowest: compound 4; then compounds 3, 1 and 2 (each within the scatter of the next).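

Going by these compounds alone, this is the first step that can be read as a single change. In this assay, 3-methoxyphenyl in place of 4-fluorophenyl on an amine nitrogen in a ring gives a number 26.1 percentage points lower from compound 2 to compound 4 (beyond the scatter). Within the data shown here, the earlier numbers all lay within the scatter of each other and no two of those compounds differed in one place, whereas this step shows that the group at this position can clearly alter the read-out.

No measurement shown accounts for the drop. On these data alone, the step also changes both the substituent and its printed ring position at once, so it remains open whether 4-methoxyphenyl or 3-fluorophenyl would read closer to compound 2 or to compound 4.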